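Methyl in Place of Chloro: a Small Expected Step

The compounds below may be only part of what the source reports. "The series", "measured", "known", "first", "only" and "open" are said of these compounds alone.

Three compounds have so far been measured in a functional assay on A549 cells (Homo sapiens) for cytotoxicity, read by MTT assay, with a stated time of 48 h; on this read-out higher numbers stand for weaker inhibition and lower numbers for stronger inhibition:
- compound 1, `Cc1ccc(C(=O)c2cc(F)c(OCC(=O)NNC(=O)c3ccc(=O)oc3)c(Cl)c2)cc1`, gives 22600 nM
- compound 2, `Cn1cnc(C(=O)NNC(=O)COc2c(F)cc(C(=O)c3ccc(F)cc3)cc2Cl)c1`, gives 40100 nM
- compound 3, `Cn1cnc(C(=O)NNC(=O)COc2c(F)cc(C(=O)c3ccc(Cl)cc3)cc2Cl)c1`, gives 49100 nM

Compound 3 carries the highest number of the three. Its nearest neighbour is compound 2, and the two lie within the usual scatter of each other, so no order can be read between them. Compound 1 is furthest away, with a number lower than that of compound 3 beyond the scatter.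

Compound 4, `Cc1ccc(C(=O)c2cc(F)c(OCC(=O)NNC(=O)c3cn(C)cn3)c(Cl)c2)cc1`, has not been measured. It differs from compound 3 in one place: methyl in place of chloro on an aromatic carbon.

Among the compounds with values here, only one measured step speaks to such an exchange on that ring. From compound 2 to compound 3, a 1.2-fold higher number from compound 2 to compound 3 (0.09 log units; within the scatter), and that change stayed within the scatter. Compound 1 also carries the 4-methylphenyl group, but it differs from compound 4 elsewhere in the molecule as well, so it offers no clean comparison; its value simply shows that a compound with this group can sit at a lower number.

On this basis the step from compound 3 to compound 4 is expected to be small, a 1.3-fold lower number from compound 3 to compound 4 (0.11 log units; within the scatter), if anything a slightly lower number. Compound 4 is therefore estimated at 38000 nM, within a range from 18000 nM to 80000 nM.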

Compound 4, half-maximal inhibitory concentration: 8800 nM
For compound 4 the middle estimate is 4.3-fold (0.64 log units) above the measured one, and the stated range ends above it.
By their numbers in this assay, from the lowest: compound 4; then compounds 1, 2 and 3 (each within the scatter of the next, the first and the last beyond it).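

In this assay, within the data shown here, the group at this position does matter, although the earlier compounds gave no sign of it: exchanging one halogen for the other changed little (a 1.2-fold higher number from compound 2 to compound 3 (0.09 log units; within the scatter)), whereas methyl in place of chloro gives a clear step (a 5.6-fold lower number from compound 3 to compound 4 (0.75 log units; beyond the scatter)). Methyl in place of fluoro gives a step of similar size (a 4.6-fold lower number from compound 2 to compound 4 (0.66 log units; beyond the scatter)), so within this series the 4-methylphenyl compound stands apart from both 4-halophenyl compounds, and no reason for this can be drawn from the information at hand. With the 4-methylphenyl group held constant, the other end of the molecule also counts, as the five-membered ring of compound 4 in place of the six-membered ring of compound 1 gives a further step (a 2.6-fold lower number from compound 1 to compound 4 (0.41 log units; beyond the scatter)).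

The compounds shown leave open whether the effect belongs to methyl alone or would extend to a longer chain such as ethyl, or to a methoxy group or an amine at the same position. They also leave open whether the exchange of chloro for methyl would give a similar step on the six-membered ring partner found in compound 1.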